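p300 inhibition: an indazolyl head in place of compound 1's

The compounds below may be only part of what the source reports. "The series", "measured", "known", "first", "only" and "open" are said of these compounds alone.

The measured compounds in an assay on isolated protein for inhibition of histone acetyltransferase p300 (Homo sapiens), with a stated time of 60 min (a lower number here means a stronger inhibitor, a higher number a weaker inhibitor), are:
compound 1, `O=C(Nc1ccc2[nH]c(=O)[nH]c2c1)[C@H]1CCCN1C(=O)C1(c2cccc(Cl)c2)CCCC1`, 0.398 nM
compound 2, `COc1ccc(NC(=O)[C@H]2CCCN2C(=O)C2(c3ccc(Cl)cc3)CCC2)cc1`, 10 nM
compound 3, `CNC(=O)c1ccc(NC(=O)[C@H]2CCCN2C(=O)C2(c3cccc(Cl)c3)CCCC2)cc1`, 0.794 nM

Compound 1 gives the lowest of these three numbers. Its nearest neighbour is compound 3, with a 2.0-fold higher number from compound 1 to compound 3 (0.30 log units; within the scatter), a change that stays within the scatter. Compound 2 lies furthest away, and since it differs from compound 1 in more than one place, only the two values themselves can be compared: the gap between them is beyond the scatter.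

The new compound is compound 4, `O=C(Nc1ccc2[nH]ncc2c1)[C@H]1CCCN1C(=O)C1(c2cccc(Cl)c2)CCCC1`. It differs from compound 1 in one place: a group of 9 heavy atoms (7 carbon, 2 nitrogen; one five-membered aromatic ring with 2 hetero atoms, one six-membered aromatic ring of carbon only) in place of a group of 10 heavy atoms (7 carbon, 2 nitrogen, 1 oxygen; one five-membered aromatic ring with 2 hetero atoms, one six-membered aromatic ring of carbon only), on an amide-type nitrogen.

Among the compounds with values here, the only step that bears on this change is a 2.0-fold higher number from compound 1 to compound 3 (0.30 log units; within the scatter), which replaced the same group on the amide-type nitrogen with a different one and produced no shift beyond the scatter. That is a thin basis, and the entering 1H-indazol-5-yl group has not been seen in any measured compound here. On this evidence the expectation for compound 4 in this assay is a step of about a 2.5-fold higher number from compound 1 to compound 4 (0.40 log units; beyond the scatter), most likely within the scatter, with a mild lean toward a higher number. The estimate for compound 4 is therefore 1 nM, in a range from 0.3 nM to 4 nM.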

Compound 4, half-maximal inhibitory concentration: 1 nM
For compound 4 middle estimate and measured number coincide at the digits printed; the measured number falls inside the stated range.
By their numbers in this assay, from the lowest: compounds 1, 3 and 4 (each within the scatter of the next, the first and the last beyond it); then compound 2.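

In this assay, within the data shown here, the 1H-indazol-5-yl group gives a 2.5-fold higher number from compound 1 to compound 4 (0.40 log units; beyond the scatter), a modest change and the first step on this amide-type nitrogen to pass beyond the scatter. Compared with the group it replaces, the entering group has one heavy atom fewer, one hydrogen-bond donor fewer and no double bond outside its aromatic rings, but this single step cannot show which of these differences matters, if any. The second step, a 1.3-fold higher number from compound 3 to compound 4 (0.10 log units; within the scatter), stays within the scatter, so this assay does not separate the 1H-indazol-5-yl group from 4-(methylcarbamoyl)phenyl, and no measurement offered here accounts for either step.

As far as these compounds go, what remains open is how this amide-type nitrogen would respond to a plain phenyl, or to a phenyl carrying a carboxylic acid or an amine. From the compounds shown here alone, compounds 1, 3 and 4 also share the rest of the core of compound 1, so it remains unknown whether the same steps would hold on a different core.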